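Compound 3 at the limit of the assay

This account rests on a few compounds, and the source may have more. Where it says the series, first, only, none or still open, it means among the compounds named here.

Compound 1 `CC(=O)Nc1ccc2oc(-c3cccc(F)c3)cc(=O)c2c1`: > 125000 nM (a limit)
Compound 2 `COc1cccc(-c2cc(=O)c3cc(N)ccc3o2)c1`: > 125000 nM (a limit)

In an ADME assay on THP-1 cells (Homo sapiens) for cytotoxicity, read by flow cytometry and propidium iodide staining, with a stated time of 72 h (a higher number here means a weaker inhibitor, a lower number a stronger inhibitor), compound 2 stands at > 125000 nM, which is a limit of the assay and not a number. Compound 1 reads > 125000 nM, which is likewise a limit. For the measured compounds named here, the whole record in this assay so far therefore comes down to the limit of > 125000 nM in this assay, at which 2 of the 2 values shown sit.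

Compound 3 `Nc1ccc2oc(-c3cccc(F)c3)cc(=O)c2c1` has not yet been measured. It differs from compound 2 in one place: fluoro in place of methoxy on an aromatic carbon. This is fluoro in place of methoxy on an aromatic carbon, meta to a large group.

Going by the values given here, no measured step is available to show what such a change does in this assay, so no shift beyond the usual scatter is expected in either direction. That expectation rests on compound 2, whose limit of > 125000 nM gives no number to step from. The estimated step of a number no higher from compound 2 to compound 3 (the limit leaves the size open) is expected to stay within the scatter. For compound 3, the estimated value is 125000 nM, with an expected range from 50000 nM to 250000 nM, and a report at the limit is the likeliest outcome.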

Compound 3, half-maximal inhibitory concentration: > 125000 nM
Compound 3 was reported as a limit (the forecaster's own chance of this, stated with the estimate: 80%); the middle value lies on the limit itself.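

Compound 3 reads > 125000 nM, which is a limit of the assay and not a number. For the compounds shown here, no step from compound 1 or compound 2 to compound 3 can be read, because all three compounds end at the same limit: the limit of > 125000 nM in this assay, at which 3 of the 3 values shown sit. The compounds shown leave open whether fluoro in place of methoxy, or hydrogen in place of acetyl on a nitrogen, changes the outcome in this assay at all.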